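A few compounds are considered here, and "the series" means these few. Any claim that something is new, unique, unknown or untested is made for them only; others in the source may bear on it.

In a functional assay on ACHN cells (Homo sapiens) for cytotoxicity, read by sulforhodamine B assay, with a stated time of 72 h (on this read-out higher numbers stand for weaker inhibition of growth and lower numbers for stronger inhibition of growth), the three measured compounds give:

- compound 1, `COc1ccc(NC(=O)C2CCc3ccccc3N2)cc1`: 38000 nM
- compound 2, `O=C(Nc1cc(C(F)(F)F)cc(C(F)(F)F)c1)C1CCc2ccccc2N1C(=O)c1ccccc1Cl`: 4700 nM
- compound 3, `O=C(Nc1ccccc1C(F)(F)F)C1CCc2ccccc2N1`: 57600 nM

Compound 2 gives the lowest number of the three, and the gaps to compound 1 and to compound 3 both lie beyond the usual scatter, so compound 2 is the strongest inhibitor of growth here. Compound 4, `O=C(Nc1cc(C(F)(F)F)cc(C(F)(F)F)c1)C1CCc2ccccc2N1`, is not yet measured. It differs from compound 2 in one place: hydrogen in place of (2-chlorophenyl)carbonyl on a nitrogen on an aromatic ring in a ring. Compound 4 thus shares the unsubstituted ring nitrogen of compound 1 and compound 3, which give only weak inhibition. The step of a 6.4-fold higher number from compound 2 to compound 4 (0.81 log units; beyond the scatter) is therefore expected to go toward a higher number, well beyond the scatter. Compound 4 is expected to give about 30000 nM, within a range of 8000 nM to 100000 nM.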

Compound 4, concentration for 50% growth inhibition: 8190 nM
Compound 4: middle estimate off by 3.7-fold (0.56 log units), on the high side; measured number inside the range.
By their numbers in this assay, from the lowest: compounds 2 and 4 (each within the scatter of the next); then compounds 1 and 3 (each within the scatter of the next).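

In this assay, replacing the (2-chlorophenyl)carbonyl on the ring nitrogen with hydrogen gives a 1.7-fold higher number from compound 2 to compound 4 (0.24 log units; within the scatter). With the rest of the molecule unchanged, this nitrogen can therefore carry that whole aromatic group or just hydrogen, and the two read-outs cannot be told apart. Nothing available explains this result. The compounds shown leave open how a smaller group on this nitrogen, such as acetyl or methyl, would read. They also leave open whether (2-chlorophenyl)carbonyl would give a similar result on the core of compound 1 or compound 3.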